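The source may hold more compounds than are shown below. What is called first, only, known or untested is meant among the compounds shown, and "the series" means these compounds.

Measured so far in a functional assay on A549 cells (Homo sapiens) for antiproliferative activity, read by MTT assay, with a stated time of 72 h; on this read-out higher numbers stand for weaker inhibition and lower numbers for stronger inhibition:
- compound 1 (`NC1=NC2(CCOCC2)N(OCCCOc2ccccc2)C(N)=N1`) gives 1080 nM
- compound 2 (`Cc1ccc(OCCCON2C(N)=NC(N)=NC23CCOCC3)cc1`) gives 1060 nM

Compound 2 at 1060 nM stands level with compound 1 at 1080 nM within the scatter, so neither can be ranked above the other. Next is compound 3 (`NC1=NC2(CCOCC2)N(OCCCOc2ccc(Br)cc2)C(N)=N1`). The change is bromo in place of methyl on an aromatic carbon, para to a large group. For the measured compounds named here, one measured step bears on it: a 1.0-fold lower number from compound 1 to compound 2 (0.01 log units; within the scatter), methyl in place of hydrogen on an aromatic carbon, and this lies within the scatter. Going by the values given here, no measured compound carries bromo, so this evidence is indirect. No step beyond the scatter is expected in this assay. The expected step is small (a 1.1-fold lower number from compound 2 to compound 3 (0.03 log units; within the scatter)). For compound 3 the estimated value is 1000 nM, with an expected range from 450 nM to 2200 nM.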

Compound 3, half-maximal inhibitory concentration: 280 nM
The estimate for compound 3 lay 3.6-fold (0.55 log units) above the measured number; the measured number lies below the stated range.
By their numbers in this assay, from the lowest: compound 3; then compounds 2 and 1 (each within the scatter of the next).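

In this assay the position para to a large group is not indifferent to substitution: bromo in place of methyl gives a 3.8-fold lower number from compound 2 to compound 3 (0.58 log units; beyond the scatter), and bromo in place of hydrogen gives a 3.9-fold lower number from compound 1 to compound 3 (0.59 log units; beyond the scatter), both beyond the scatter. The earlier step, a 1.0-fold lower number from compound 1 to compound 2 (0.01 log units; within the scatter), lay within the scatter, so the flat picture it gave holds for methyl only and not for the position as a whole. No measurement shown accounts for the gain seen with bromo.

As far as these compounds go, with only hydrogen, methyl and bromo at this position, it remains open whether chloro, fluoro or methoxy would track bromo or methyl. From the compounds shown here alone, it also remains open whether the 4-bromophenoxy gain would persist with a longer chain linking that ring to the shared core.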